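This account rests on a few compounds, and the source may have more. Where it says the series, first, only, none or still open, it means among the compounds named here.

Measured in an ADME assay (liver) for metabolic stability, with Liver microsome (Rattus norvegicus) as the target, using microsomes and NADPH, with a stated time of 30 min, tested at 1 uM; a lower number here means slower removal, a higher number faster removal of the compound:
- Compound 1 `Nc1ccc(S(=O)(=O)N2CCN(c3ncc(C(O)(C(F)(F)F)C(F)(F)F)cc3Br)CC2)cn1`: 32 mL.min-1.g-1
- Compound 2 `CCn1cc(-c2cc(C(O)(C(F)(F)F)C(F)(F)F)cnc2N2CCN(S(=O)(=O)c3ccc(N)nc3)CC2)cn1`: 194 mL.min-1.g-1
- Compound 3 `CC(C)n1cc(-c2cc(C(O)(C(F)(F)F)C(F)(F)F)cnc2N2CCN(S(=O)(=O)c3ccc(N)nc3)CC2)cn1`: 198 mL.min-1.g-1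

At 198 mL.min-1.g-1, compound 3 belongs to the upper pair of these three numbers. Methyl in place of hydrogen on the pyrazole's side chain gives a 1.0-fold higher number from compound 2 to compound 3 (0.01 log units; within the scatter). The next change replaces 1-isopropyl-1H-pyrazol-4-yl with 3-carbamoylphenyl on an aromatic carbon, giving compound 4 `NC(=O)c1cccc(-c2cc(C(O)(C(F)(F)F)C(F)(F)F)cnc2N2CCN(S(=O)(=O)c3ccc(N)nc3)CC2)c1` (3-carbamoylphenyl in place of 1-isopropyl-1H-pyrazol-4-yl on an aromatic carbon).

Two measured steps show that this place on the shared core matters. Putting 1-ethyl-1H-pyrazol-4-yl in place of bromo gives a 6.1-fold higher number from compound 1 to compound 2 (0.78 log units; beyond the scatter), and putting 1-isopropyl-1H-pyrazol-4-yl there gives a 6.2-fold higher number from compound 1 to compound 3 (0.79 log units; beyond the scatter). Within the data shown here, no measured compound carries a 3-carbamoylphenyl group, so these steps suggest a possible size but do not fix a direction. With compound 3 in the upper pair and compound 1 far lower at 32 mL.min-1.g-1, a modest fall in this assay seems the likelier outcome, though this is uncertain. The expected change is a 2.2-fold lower number from compound 3 to compound 4 (0.34 log units; beyond the scatter). For compound 4 the estimated value is 90 mL.min-1.g-1, with an expected range of 35 mL.min-1.g-1 to 220 mL.min-1.g-1.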

Compound 4, intrinsic clearance in microsomes: 63 mL.min-1.g-1
Compound 4: the middle estimate sits 1.4-fold (0.15 log units) above what was measured; measured number inside the range.
By their numbers in this assay, from the lowest: compounds 1 and 4 (each within the scatter of the next); then compounds 2 and 3 (each within the scatter of the next).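

In this assay, a ring at this place on the shared core does not have to bring the high numbers seen with the two pyrazoles. Changing to 3-carbamoylphenyl gives a 3.1-fold lower number from compound 3 to compound 4 (0.50 log units; beyond the scatter) and, from the ethyl analogue, a 3.1-fold lower number from compound 2 to compound 4 (0.49 log units; beyond the scatter), while against the bromo group it gives a 2.0-fold higher number from compound 1 to compound 4 (0.29 log units; within the scatter), so the ring type matters and not merely the replacement of bromo by a ring. No measurement available here accounts for this difference between the rings.

From the compounds shown here alone, how much of the change belongs to the phenyl ring and how much to the carbamoyl group stays open, and plain phenyl, or phenyl bearing a carboxylic acid or an amine instead, would separate the two. Also open, going by these compounds, is whether 4-carbamoylphenyl would behave like 3-carbamoylphenyl.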